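The source may report more compounds than this note shows. Statements on the series, on what has been measured and on what is new or still open speak of the compounds shown alone.

Working notes on the series. Among the compounds with values here, compound 3 `N#Cc1cccc(-c2cnc(C(=O)CCCCCCc3ccccc3)o2)c1` gives 15 nM in an assay (Rattus norvegicus) for inhibition of Fatty-acid amide hydrolase 1 (Homo sapiens) (a higher number here means a weaker inhibitor, a lower number a stronger inhibitor), the lowest of the three numbers so far; compound 1 `Nc1cccc(-c2cnc(C(=O)CCCCCCc3ccccc3)o2)c1` gives 19 nM, and compound 2 `O=C(CCCCCCc1ccccc1)c1ncc(-c2cccc(O)c2)o1` gives 50 nM. Within the data shown here, the step of a 1.3-fold lower number from compound 1 to compound 3 (0.10 log units; within the scatter) lies within the scatter, whereas a 3.3-fold lower number from compound 2 to compound 3 (0.52 log units; beyond the scatter) and a 2.6-fold higher number from compound 1 to compound 2 (0.42 log units; beyond the scatter) go beyond it, so the only change that moved the number was the hydroxy substituent, which carries a hydrogen-bond donor.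

Compound 4 `O=C(O)c1ccc(-c2cnc(C(=O)CCCCCCc3ccccc3)o2)cc1` differs from compound 3 by 4-carboxyphenyl in place of 3-cyanophenyl on an aromatic carbon. Among the measured compounds shown here, no measured step covers this change: the carboxyphenyl group introduces a hydrogen-bond donor, as the hydroxy of compound 2 did, and it sits at a different position of the aryl group than any substituent measured so far. For the measured compounds named here, the only bearing steps are those above; they show the donor-bearing compound 2 weakest and everything else within a narrow band.

Compound 4 is therefore expected to give a modestly higher number, a 4.0-fold higher number from compound 3 to compound 4 (0.60 log units; beyond the scatter), landing at 60 nM with a range of 20 nM to 200 nM in this assay.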

Compound 4, inhibition constant: 60 nM
The estimate for compound 4 equals the measured number at the digits printed, and the stated range covers the measured number.
By their numbers in this assay, from the lowest: compounds 3 and 1 (each within the scatter of the next); then compounds 2 and 4 (each within the scatter of the next).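

In this assay, 4-carboxyphenyl behaves unlike 3-cyanophenyl and 3-aminophenyl, with a 4.0-fold higher number from compound 3 to compound 4 (0.60 log units; beyond the scatter) and a 3.2-fold higher number from compound 1 to compound 4 (0.50 log units; beyond the scatter), yet it stays level with 3-hydroxyphenyl, with a 1.2-fold higher number from compound 2 to compound 4 (0.08 log units; within the scatter). A hydrogen-bond donor on the aryl group therefore fits compound 2 and compound 4, but compound 1, whose amino group also carries one, goes against that pattern. Nothing on hand accounts for these shifts.

Compound 4 changes both the group and its place on the aryl ring, so the compounds shown leave open which of the two sets its number. A 3-carboxyphenyl or 4-cyanophenyl group would separate them, and a methyl ester of the carboxylic acid would show whether the acid hydrogen matters.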